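The source may report more compounds than this note shows. Statements on the series, on what has been measured and on what is new or still open speak of the compounds shown alone.

Working notes on the series.

In an assay on SH-SY5Y cells for inhibition of Voltage-dependent N-type calcium channel subunit alpha-1B (Homo sapiens), read by FLIPR and calcium flux, with stated times of 600 s and 300 s, in the presence of a further agent that is not named here (on this read-out lower numbers stand for stronger inhibition and higher numbers for weaker inhibition), compound 3 `CN(Cc1ccc(OCCCNC(=N)N)cc1)c1nc2ccc(Oc3ccc(O)cc3)cc2s1` gives 432000 nM, the highest number among the measured compounds. Its nearest neighbour is compound 1 `N=C(N)NCCCOc1ccc(CNc2nc3ccc(Oc4cccc(C(F)(F)F)c4)cc3s2)cc1`, which in this assay gives 130000 nM; compound 2 `CN(Cc1ccc(OCCCNC(=N)N)cc1)c1nc2ccc(Oc3ccc(F)cc3)cc2s1` in this assay gives 100000 nM. For the measured compounds named here, the only single-point step recorded is a 4.3-fold higher number from compound 2 to compound 3 (0.64 log units; beyond the scatter), brought about by hydroxy in place of fluoro on an aromatic carbon.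

Compound 4 `CN(Cc1ccc(OCCCNC(=N)N)cc1)c1nc2ccc(Oc3cccc(C(F)(F)F)c3)cc2s1` differs from compound 3 by 3-(trifluoromethyl)phenyl in place of 4-hydroxyphenyl on an oxygen on an aromatic ring. The step that bears on it is a 4.3-fold higher number from compound 2 to compound 3 (0.64 log units; beyond the scatter), which runs in the opposite sense: it shows that removing the hydroxy-bearing ring in favour of a ring with no hydrogen-bond donors or acceptors is accompanied by a lower number. Compound 1 already carries 3-(trifluoromethyl)phenyl on the same oxygen, and its value of 130000 nM sits close to compound 2. The expectation for compound 4 is therefore a modest drop, estimated as a 3.9-fold lower number from compound 3 to compound 4 (0.59 log units; beyond the scatter), back toward the values of compound 1 and compound 2. Compound 4 is estimated at 110000 nM, with a range from 50000 nM to 250000 nM.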

Compound 4, half-maximal inhibitory concentration: 202000 nM
Beside the measured number, compound 4's estimate is 1.8-fold (0.26 log units) below it; the measured number falls inside the stated range.
By their numbers in this assay, from the lowest: compounds 2, 1 and 4 (each within the scatter of the next, the first and the last beyond it); then compound 3.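

In this assay, the group on this oxygen moves the number in both directions: 3-(trifluoromethyl)phenyl in place of 4-hydroxyphenyl gives a 2.1-fold lower number from compound 3 to compound 4 (0.33 log units; beyond the scatter), while the same group in place of 4-fluorophenyl gives a 2.0-fold higher number from compound 2 to compound 4 (0.31 log units; beyond the scatter), so all three groups separate beyond the scatter, with 4-fluorophenyl lowest and 4-hydroxyphenyl highest. With 3-(trifluoromethyl)phenyl held fixed, methyl in place of hydrogen on a nitrogen on an aromatic ring gives a 1.6-fold higher number from compound 1 to compound 4 (0.19 log units; within the scatter), so this change cannot be told apart from repeat variation. No evidence on the cause of these shifts is available.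

Still open, going by these compounds, is how a plain phenyl or a 4-(trifluoromethyl)phenyl would read on the same oxygen, since 4-fluorophenyl and 3-(trifluoromethyl)phenyl differ in both the group and its place on the ring. Also open, on these data alone, is whether an amine or a carboxylic acid in place of the hydroxy would track compound 3.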